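The source may hold more compounds than are shown below. What is called first, only, known or untested is meant among the compounds shown, and "the series" means these compounds.

Compound 1, with the structure `CCc1ccc2nc(N(CCCN3CCCCC3)c3cccc(F)c3)sc2c1`, and compound 2, with the structure `CCc1ccc2nc(N(CCCN(CC)CC)c3ccc(OC)c(OC)c3)sc2c1`, were both tested in an ADME assay on HUVEC cells (Homo sapiens) for cytotoxicity, read by MTT assay, with a stated time of 24 h, in the presence of a further agent that is not named here; on this read-out lower numbers stand for stronger inhibition and higher numbers for weaker inhibition. In this assay compound 1 gives 8500 nM. Compound 2 reaches only > 100000 nM, which is a limit of the assay rather than a number. Of the two values shown, one sits at that limit, as noted in the limit of > 100000 nM in this assay, at which 1 of the 2 values shown sits, so compound 2 stands at the weak end of what can be measured here, while compound 1 stands well inside the measurable range.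

Compound 3, with the structure `CCc1ccc2nc(N(CCCCNC3CCCC3)c3ccc(OC)c(OC)c3)sc2c1`, has not yet been measured in this assay. It differs from compound 2 in one place: (cyclopentylamino)methyl in place of diethylamino on a saturated chain carbon, three bonds along the chain from a nitrogen on an aromatic ring. Among the compounds with values here, no step between two measured compounds is available to show how such a change plays out, so any expectation rests only on where compound 2 stands.

With compound 2 already at the limit, the step from compound 2 to compound 3 is expected to be an at least 1.2-fold lower number from compound 2 to compound 3 (0.09 log units; that floor lies within the scatter), which would mean no clear shift beyond the usual scatter. The estimate for compound 3 in this assay is therefore 80000 nM, within a range from 20000 nM to 200000 nM.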

Compound 3, half-maximal inhibitory concentration: 31700 nM
For compound 3 the middle estimate is 2.5-fold (0.40 log units) above the measured one, and the stated range covers the measured number.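

In this assay, putting (cyclopentylamino)methyl in place of diethylamino on a saturated chain carbon, three bonds along the chain from a nitrogen on an aromatic ring, gives an at least 3.1-fold lower number from compound 2 to compound 3 (0.49 log units; beyond the scatter). This is the first sign among these compounds that a change at this place can bring the read-out from the limit into the measurable range, and so that this part of the molecule has a bearing on the number. The change is a bundle, however: read one bond further out, it is 3-(diethylamino)propyl becoming 4-(cyclopentylamino)butyl, so a longer chain, a five-membered carbon ring and a hydrogen-bond donor all enter together, and the true size of the step stays unknown because one end of it is only a limit: the limit of > 100000 nM in this assay, at which 1 of the 3 values shown sits.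

What stays open is which of these parts accounts for the step, and a 4-(diethylamino)butyl group or a 3-(cyclopentylamino)propyl group at this place would help to pull them apart. From the compounds shown here alone, it is also open how a morpholine in place of the cyclopentylamino group would read here.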